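The compounds below may be only part of what the source reports. "The series", "measured", "known", "first", "only" and "open" are said of these compounds alone.

Working notes on the series. Three compounds of the shared core carry measurements in a functional assay on A549 cells (Homo sapiens) for antiproliferative activity, read by MTT assay, with a stated time of 48 h; a higher number here means a weaker inhibitor, a lower number a stronger inhibitor. Compound 1 `COC/C1=C/C[C@](C)(CCC=C(C)C)/C=C/[C@@H](OC(=O)C=C(C)C)[C@](C)(OC)/C=C/C1=O` gives 4180 nM. Compound 2 `CC(C)=CCC[C@]1(C)/C=C/[C@@H](OC(=O)C=C(C)C)[C@](C)(O)/C=C/C(=O)/C(CN2CCN(C)CC2)=C\C1` gives 940 nM. Compound 3 `CC(C)=CCC[C@](C)(/C=C/[C@@H](OC(=O)C=C(C)C)[C@](C)(O)/C=C/C(=O)/C=C/N1CCN(C)CC1)CC=O` gives 2660 nM. Compound 2 therefore stands lowest of the three numbers; its gap to compound 3 is the smaller one and its gap to compound 1 the larger, and both lie beyond the usual scatter, so compound 2 is the strongest inhibitor measured so far.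

Compound 4 `CC(C)=CCC[C@]1(C)/C=C/[C@@H](OC(=O)C=C(C)C)[C@](C)(O)/C=C/C(=O)/C(C(=O)N(C(C)C)C(C)C)=C\C1` is not yet measured. It differs from compound 2 in one place: diisopropylcarbamoyl in place of (4-methylpiperazin-1-yl)methyl on a double-bonded ring carbon. Going by the values given here, no measured pair differs in a single place, so no measured step bears directly on this change; compound 1 and compound 3 each differ from compound 2 at more than one position, and both give higher numbers. The expectation for compound 4 is a moderate rise in the number, a step of a 2.1-fold higher number from compound 2 to compound 4 (0.33 log units; beyond the scatter), of a size close to the edge of the scatter. Compound 4 is thus estimated at 2000 nM, with a range from 700 nM to 6000 nM.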

Compound 4, half-maximal inhibitory concentration: 13500 nM
For compound 4 the middle estimate is 6.8-fold (0.83 log units) below the measured one; the whole stated range lies below it.
By their numbers in this assay, from the lowest: compound 2; then compounds 3 and 1 (each within the scatter of the next); then compound 4.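

Going by these compounds alone, the first step that changes one place shows this position to be sensitive to the group it carries: in this assay, diisopropylcarbamoyl in place of (4-methylpiperazin-1-yl)methyl on a double-bonded ring carbon gives a 14-fold higher number from compound 2 to compound 4 (1.16 log units; beyond the scatter). The size of this step does not follow from heavy-atom count, as the two groups hold 8 and 9 heavy atoms; they differ instead in the six-membered non-aromatic ring, which only the leaving group has, and in the double bond outside aromatic rings, which only the entering group has. Nothing measured here accounts for the rise.

The compounds shown leave open whether the rise goes with the loss of the piperazine ring or with the carbonyl on the ring carbon. A (4-methylpiperazin-1-yl)carbonyl group and a diisopropylaminomethyl group at this place would separate the two.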